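One Stereocentre Redrawn in a Cytotoxicity Comparison

This account rests on a few compounds, and the source may have more. Where it says the series, first, only, none or still open, it means among the compounds named here.

In an ADME assay on HFF cells (Homo sapiens) for cytotoxicity, read by neutral red uptake (a lower number here means that less compound is tolerated, a higher number that more compound is tolerated), compound 1 (`Nc1ncnc2c1ncn2/C=C1/C[C@H]1[C@H](O)CO`) gives 206000 nM as its measured reading. Compound 2 (`Nc1nc2c(ncn2/C=C2/C[C@@H]2[C@@H](O)CO)c(=O)[nH]1`) is recorded as > 300000 nM and this is a limit of the assay, not a number, so only a limit is known for it. The next compound, compound 3 (`Nc1nc2c(ncn2/C=C2/C[C@@H]2[C@H](O)CO)c(=O)[nH]1`), is very close to compound 2 in structure, and the difference is easily stated: the two compounds have the same atoms and bonds and differ only in configuration as drawn: 1 of 3 stereo elements differ; a stereocentre at a saturated chain carbon is drawn R in compound 2 and S in compound 3 (nothing else changes). Going by the values given here, no measured pair here shows what redrawing such a stereocentre does to the reading, so no direction can be foreseen. In this assay the expected change, a number no higher from compound 2 to compound 3 (the limit leaves the size open) by estimate, should stay within the usual scatter of repeated measurements. The estimated value for compound 3 is 300000 nM with an expected range of 170000 nM to 450000 nM for the reading, and a reading that is again only a limit would be no surprise.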

Compound 3, half-maximal cytotoxic concentration: > 300000 nM
Compound 3 was reported as a limit; the forecaster's own chance of this, stated with the estimate: 70%; the middle value sits exactly at the limit.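

No step can be read from compound 2 to compound 3, because in this assay each compound is reported only as a limit, not as a number: the limit of > 300000 nM in this assay, at which 2 of the 3 values shown sit.

The compounds shown leave open whether redrawing this stereocentre at a saturated chain carbon changes the reading at all.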